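The compounds below may be only part of what the source reports. "The series", "measured", "known", "first", "only" and "open" are said of these compounds alone.

Four compounds built on a phenyl-pyrazole chalcone scaffold are compared in a functional assay on Huh-7 cells (Homo sapiens) for inhibition, read by sulforhodamine B assay, with a stated time of 72 h; on this read-out lower numbers stand for stronger inhibition and higher numbers for weaker inhibition. Compound 1 `COc1cc(OC)c(C(=O)/C=C/c2cn(-c3ccccc3)nc2-c2ccsc2)c(OC)c1` gives 6100 nM in this assay. Compound 2 `COc1ccc(C(=O)/C=C/c2cn(-c3ccccc3)nc2-c2ccsc2)c(OC)c1OC` is made of the same atoms as compound 1 joined differently; the difference between the two cores is not broken down here. In this assay compound 2 gives 4200 nM, a number that lies within the usual scatter of the value of compound 1, so the two cannot be ranked against each other on these data.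

Compound 3 `COc1cc(OC)c(C(=O)/C=C/c2cn(-c3ccccc3)nc2-c2cccnc2)c(OC)c1` differs from compound 1 in one place, namely (pyridin-3-yl in place of thiophen-3-yl on an aromatic carbon). In this assay compound 3 gives 500 nM. The step amounts to a 12-fold lower number from compound 1 to compound 3 (1.09 log units; beyond the scatter), the only large movement among the three measured compounds.

Compound 4 `COc1ccc(C(=O)/C=C/c2cn(-c3ccccc3)nc2-c2cccnc2)c(OC)c1OC` has not yet been measured. Among the measured compounds shown here, it differs from compound 2 by pyridin-3-yl in place of thiophen-3-yl on an aromatic carbon, which is the same change at the same place as the one taken from compound 1 to compound 3. The expectation for compound 4 rests on that single measured step; nothing else in the set speaks to how far the change carries over onto the core of compound 2. The step from compound 2 to compound 4 is estimated at a 9.3-fold lower number from compound 2 to compound 4 (0.97 log units; beyond the scatter), set a little short of the earlier step to allow for a single prior instance. Compound 4 is therefore expected to give about 450 nM in this assay, with a likely range from 150 nM to 1500 nM.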

Compound 4, half-maximal inhibitory concentration: 2300 nM
Estimate against measurement, compound 4: 5.1-fold (0.71 log units) below, outside the stated range (above it).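

On the core of compound 2, putting pyridin-3-yl in place of thiophen-3-yl gives a 1.8-fold lower number from compound 2 to compound 4 (0.26 log units; within the scatter) in this assay, so on this core the change has no effect that can be told from the scatter. Among the compounds shown here, the large step seen on the core of compound 1 therefore did not carry over to the core of compound 2, and the two steps differ by more than their scatter, which means the size of this change depends on the core that carries it: the same change on two cores in this assay, a 12-fold lower number (1.09 log units; beyond the scatter) from compound 1 to compound 3 and a 1.8-fold lower number (0.26 log units; within the scatter) from compound 2 to compound 4, 6.7-fold (0.82 log units) apart, beyond the scatter of two such steps This rests on only two pairs of compounds, so it shows that the step cannot simply be transferred between these two cores, but it does not show what in the cores causes the difference or how the change would behave on any further core.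

The compounds shown leave open whether this dependence on the core is particular to the exchange of thiophen-3-yl and pyridin-3-yl or also holds for other groups at the same place, such as an amine or a carboxylic acid. They also leave open how either group would fare on a core joined differently from these two.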